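The source may hold more compounds than are shown below. What is called first, only, known or untested is meant among the compounds shown, and "the series" means these compounds.

Measured in a functional assay on MCF7 cells (Homo sapiens) for antiproliferative activity, read by CellTiter-Glo, with a stated time of 5 days; on this read-out higher numbers stand for weaker inhibition and lower numbers for stronger inhibition:
- compound 1 `N#Cc1ccc(/C(=C(\c2ccc(/C=C/C(=O)O)cc2)c2ccc(-c3cncs3)cc2)C2CCC2)c(Cl)c1`: 2.9 nM
- compound 2 `N#Cc1cc(Cl)ccc1/C(=C(\c1ccc(/C=C/C(=O)O)cc1)c1ccc(-c2cncs2)cc1)C1CCC1`: 4.3 nM
- compound 3 `O=C(O)/C=C/c1ccc(/C(=C(\c2ncc(C(F)(F)F)cc2Cl)C2CCC2)c2ccc(-c3cncs3)cc2)cc1`: 7.3 nM

Only the outer two of these three numbers are separated beyond the scatter, a 2.5-fold higher number from compound 1 to compound 3 (0.40 log units; beyond the scatter). Compound 2, at 4.3 nM, lies within the scatter of both others: a 1.5-fold higher number from compound 1 to compound 2 (0.17 log units; within the scatter), and a 1.7-fold higher number from compound 2 to compound 3 (0.23 log units; within the scatter).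

The next compound is compound 4 `N#Cc1cc(Cl)ccc1/C(=C(\c1ccc(/C=C/C(=O)O)cc1)c1ccc(-c2cn[nH]c2)cc1)C1CCC1`, which carries 1H-pyrazol-4-yl in place of 1,3-thiazol-5-yl on an aromatic carbon, para to a large group: 1H-pyrazol-4-yl in place of 1,3-thiazol-5-yl on an aromatic carbon.

Among the compounds with values here, no measured step touches this position. All three exchange the other aromatic group, so they bear on the change only indirectly, and the series offers no direct evidence on the new ring. The largest of them is small, a 2.5-fold higher number from compound 1 to compound 3 (0.40 log units; beyond the scatter), which gives a rough sense of scale and no direction.

In this assay the expected step is a 1.1-fold lower number from compound 2 to compound 4 (0.03 log units; within the scatter), which means no expected change beyond the scatter.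

For compound 4 the estimated value is 4 nM, with an expected range of 1.5 nM to 12 nM.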

Compound 4, half-maximal inhibitory concentration: 4.4 nM
Compound 4: the middle estimate sits 1.1-fold (0.04 log units) below what was measured; the measured number falls inside the stated range.
By their numbers in this assay, from the lowest: compounds 1, 2, 4 and 3 (each within the scatter of the next, the first and the last beyond it).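

In this assay, within the data shown here, the step from 1,3-thiazol-5-yl to 1H-pyrazol-4-yl on the aromatic carbon para to a large group gives the first direct reading at this position (a 1.0-fold higher number from compound 2 to compound 4 (0.01 log units; within the scatter)), whereas the earlier steps exchanged only the other aromatic group. The 4-(1,3-thiazol-5-yl)phenyl and 4-(1H-pyrazol-4-yl)phenyl forms cannot be told apart here, although the entering ring carries a hydrogen-bond donor that the leaving ring lacks and has nitrogen where the leaving ring has sulfur. Nothing available explains why the two rings read alike.

As far as these compounds go, this is a single pair, so it remains open whether 1-methyl-1H-pyrazol-4-yl, a pyridine ring or an open-chain amine at this position would also read alike. Also open, from the compounds shown here alone, is whether 1H-pyrazol-4-yl behaves the same alongside the 2-chloro-4-cyanophenyl group of compound 1.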